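A few compounds are considered here, and "the series" means these few. Any claim that something is new, unique, unknown or untested is made for them only; others in the source may bear on it.

Compound 3 `COC(=O)[C@H]1CC[C@H](C(=O)N2CC[C@](c3ccc(C(F)(C(F)(F)F)C(F)(F)F)cc3)(S(=O)(=O)c3ccc(F)cc3)C2)CC1` carries a 4-(methoxycarbonyl)cyclohexyl group on the carbonyl carbon of its amide. In an ADME assay on microsomes from liver (Homo sapiens) for metabolic stability, with a stated time of 10 min (on this read-out lower numbers stand for a less stable compound and higher numbers for a more stable compound), compound 3 is recorded as "not determined" (no result reported); only an entry without a result exists. Its neighbours in the series do have numbers: compound 1 `O=C(O)C1CCC(O)(C(=O)N2CC[C@](c3ccc(C(F)(C(F)(F)F)C(F)(F)F)cc3)(S(=O)(=O)c3ccc(F)cc3)C2)CC1` gives 100%; 95% (2 entries) in this assay, and compound 2 `C[C@]1(C(=O)N2CC[C@](c3ccc(C(F)(C(F)(F)F)C(F)(F)F)cc3)(S(=O)(=O)c3ccc(F)cc3)C2)CC[C@@H](C(=O)O)CC1` gives 85%. The repeated entries of compound 1, (the several entries of compound 1 in this assay, 100%; 95% (2 entries)), agree closely with each other. Compound 4 `O=C(N1CC[C@](c2ccc(C(F)(C(F)(F)F)C(F)(F)F)cc2)(S(=O)(=O)c2ccc(F)cc2)C1)C1(F)CCS(=O)(=O)CC1` differs from compound 3 in one place: 4-fluoro-1,1-dioxothian-4-yl in place of 4-(methoxycarbonyl)cyclohexyl on a carbonyl carbon. Among the measured compounds shown here, no measured step connects this change to a number in this assay, so the size and direction of its effect are open. Since compound 1 gives 100%; 95% (2 entries) and compound 2 gives 85% in this assay, compound 4 is expected to stay similarly stable, estimated at 85% with a range from 60% to 100%.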

Compound 4, percent of the compound remaining: 100%
Compound 4: the middle estimate sits 15 percentage points below what was measured; low and high end bracket the measured number.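

On the carbonyl carbon, 4-fluoro-1,1-dioxothian-4-yl in place of 4-carboxy-1-methylcyclohexyl gives a number 15 percentage points higher from compound 2 to compound 4 (beyond the scatter) in this assay. The earlier numbers came only from rings carrying a carboxylic acid, whereas this group has none, so stability on this read-out does not require that acid at this place. Nothing shown explains why this group does so well.

The whole group changes in one step, so the shares of the fluorine and the ring's 1,1-dioxo sulfur stay unseparated. As far as these compounds go, how an amine or a longer chain would fare at this place remains open.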